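The source may hold more compounds than are shown below. What is called first, only, known or untested is meant among the compounds shown, and "the series" means these compounds.

The measured compounds and their values:

compound 1 `Nc1nc2cc(C(F)(F)F)ccn2c1-c1ccc(O)cc1` gives > 100000 nM
compound 2 `Nc1nc2c(C(F)(F)F)cccn2c1-c1ccc(O)cc1` gives > 100000 nM
compound 3 `Cc1ccn2c(-c3ccc(O)cc3)c(N)nc2c1` gives > 100000 nM

The three were tested in an assay on isolated protein for inhibition of ubiquitin carboxyl-terminal hydrolase 1 (Homo sapiens); a higher number here means a weaker inhibitor, a lower number a stronger inhibitor. In this assay compound 1 reaches only the limit of the assay and gives no number, > 100000 nM. Compound 2 likewise sits at the limit, with > 100000 nM. Compound 3 also returns the limit alone, > 100000 nM.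

Compound 1 and compound 3 differ in one place, (methyl in place of trifluoromethyl on an aromatic carbon). The step in this assay from compound 1 to compound 3 is a step that the two limits leave unreadable from compound 1 to compound 3, and its size cannot be read, because of the limit of > 100000 nM in this assay, at which 3 of the 3 values shown sit.

Compound 2 has the same atoms as compound 1, joined differently; the difference between the two cores is not broken down here.

The unmeasured compound 4 `Cc1cccn2c(-c3ccc(O)cc3)c(N)nc12` stands to compound 2 as compound 3 stands to compound 1: methyl in place of trifluoromethyl on an aromatic carbon. The place is not the same word for word: in compound 4 the change sits ortho to a fused ring, two atoms from the ring nitrogen and meta to a fused ring, whereas in compound 3 it sits meta to a fused ring, opposite the ring nitrogen and para to a fused ring, so this is the same kind of change rather than the same one.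

Since all three values sit at the limit, the expected step from compound 2 to compound 4 in this assay is a step that the limit leaves unreadable from compound 2 to compound 4, and this expectation rests on compound 2 giving > 100000 nM and compound 1 and compound 3 both returning the limit. Compound 4 is therefore estimated at 150000 nM, with a range from 40000 nM to 600000 nM, most likely again only a limit.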

Compound 4, half-maximal inhibitory concentration: > 100000 nM
Compound 4: no number, only a limit; the forecaster's own chance of this, stated with the estimate: 85%; the middle value lies beyond the limit too.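

In this assay compound 4 gives > 100000 nM, which is a limit and not a number. No new step can be read between compound 2 and compound 4, because both stop at a limit: the limit of > 100000 nM in this assay, at which 4 of the 4 values shown sit.

The compounds shown leave open how trifluoromethyl and methyl compare at either place, and whether any change to the shared core gives a readable value in this assay.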